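Sulfonyl aryl swap and expected microsomal clearance

A few compounds are considered here, and "the series" means these few. Any claim that something is new, unique, unknown or untested is made for them only; others in the source may bear on it.

For the measured compounds named here, compound 1 `CCn1c([C@@H](C)NS(=O)(=O)c2ccc(Cl)cc2)nc2ccc(S(C)(=O)=O)cc21` and compound 2 `CCn1c([C@@H](C)NS(=O)(=O)c2cccc(C#N)c2)nc2ccc(C(F)(F)F)cc21` share the same core but differ in more than one place, so no single step connects them. In an ADME assay (liver) for metabolic stability, with Liver microsome (Homo sapiens) as the target, read by LC-MS, using microsomes and NADPH, with a stated time of 5 min, at 37 degrees C (on this read-out higher numbers stand for fast clearance and lower numbers for slow clearance), compound 1 gives < 5 mL.min-1.g-1, which is a limit of the assay and not a number (the limit of < 5 mL.min-1.g-1 in this assay, at which 1 of the 2 values shown sits). In this assay compound 2 also returns only a limit, > 100 mL.min-1.g-1, rather than a number (the limit of > 100 mL.min-1.g-1 in this assay, at which 1 of the 2 values shown sits). Compound 2 therefore stands at the fast-clearance end of the two values shown, with only limits available on either side.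

Compound 3 `CCn1c([C@@H](C)NS(=O)(=O)c2cnc(C)n2C)nc2ccc(C(F)(F)F)cc21` is still to be run in this assay. Its change from compound 2 is 1,2-dimethyl-1H-imidazol-5-yl in place of 3-cyanophenyl on a sulfonyl sulfur. Going by the values given here, no measured step informs this change, so the direction rests on the structures alone. The step is expected to be a fall toward slower clearance, an at least 2.2-fold lower number from compound 2 to compound 3 (0.34 log units; beyond the scatter). Compound 3 is estimated to give 45 mL.min-1.g-1 in this assay, with a range from 12 mL.min-1.g-1 to 150 mL.min-1.g-1.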

Compound 3, intrinsic clearance in microsomes: 58 mL.min-1.g-1
Compound 3: the middle estimate sits 1.3-fold (0.11 log units) below what was measured, and the stated range covers the measured number.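

On the sulfonyl sulfur, whose other neighbour is the sulfonamide nitrogen, the series now has its first single-place step in this assay: an at least 1.7-fold lower number from compound 2 to compound 3 (0.23 log units; that floor lies within the scatter). With 1,2-dimethyl-1H-imidazol-5-yl at this place, compound 3 returns a measured number, where the 3-cyanophenyl compound returned only a limit. The real size of the change cannot be read, and its floor lies within the scatter, because compound 2 stands at a limit of the assay: the limit of > 100 mL.min-1.g-1 in this assay, at which 1 of the 3 values shown sits.

The compounds shown leave open whether the change depends on the imidazole ring itself or on the loss of 3-cyanophenyl, and whether a pyridine ring or an unsubstituted phenyl ring on the sulfonyl sulfur would give a similar number. Compound 1 differs from compound 2 and compound 3 in more than one place, so it does not inform this step.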